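Thioester series: phenyl for tert-butyl at the carbonyl

A few compounds are considered here, and "the series" means these few. Any claim that something is new, unique, unknown or untested is made for them only; others in the source may bear on it.

Working notes. Compound 3 `CCCOC(=O)[C@@H](N)CCC(=O)NCCSC(=O)C(C)(C)C` stands at 0.167 h in an ADME assay on liver for metabolic stability, with liver carboxylesterase 1 (Homo sapiens) as the target; on this read-out higher numbers stand for a longer-lived compound and lower numbers for a shorter-lived compound. Compound 1 `CCOC(=O)[C@@H](N)CCC(=O)NCCSC(=O)c1ccccc1` gives 0.167 h and compound 2 `CCCCOC(=O)[C@@H](N)CCC(=O)NCCSC(=O)c1ccccc1` gives 0.167 h; compound 3 is level with both at the digits shown, nearest compound 1 and furthest compound 2, with neither gap beyond the scatter. Among the measured compounds shown here, the one measured step, no change at the digits printed from compound 1 to compound 2 (within the scatter), concerns the ester alkyl chain and does not touch the carbonyl carbon whose other neighbours are sulfur. Compound 4 `CCCOC(=O)[C@@H](N)CCC(=O)NCCSC(=O)c1ccccc1` differs from compound 3 in phenyl in place of tert-butyl on a carbonyl carbon; read one bond further out, (tert-butyl)carbonyl becomes benzoyl. For the measured compounds named here, no measured step bears directly on this change. What the values do show is that compound 1 and compound 2, which carry the benzoyl group, and compound 3, which carries the (tert-butyl)carbonyl group, all sit at the same figure in this assay. On that basis no step beyond the scatter is expected, no change at the digits printed from compound 3 to compound 4 (within the scatter). Compound 4 is therefore expected at 0.167 h, with a range from 0.08 h to 0.33 h.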

Compound 4, half-life: 0.167 h
For compound 4 middle estimate and measured number coincide at the digits printed, within the range that was stated.
By their numbers in this assay, from the lowest: compounds 1, 2, 3 and 4 (each within the scatter of the next).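

In this assay phenyl in place of tert-butyl on a carbonyl carbon gives no change at the digits printed from compound 3 to compound 4 (within the scatter) as the only direct reading at this position among the compounds shown. With benzoyl held constant, the ester chain gives no change at the digits printed from compound 2 to compound 4 (within the scatter) and no change at the digits printed from compound 1 to compound 4 (within the scatter) as well, so the chain steps and the carbonyl step read alike here. No independent measurement accounts for this flat picture.

All the compounds shown sit at one figure, so nothing yet separates the groups compared at either place. From the compounds shown here alone, whether cyclohexyl or a pyridine ring on this carbonyl carbon, or a longer chain or a carboxylic acid in place of the ester, would move the half-life stays open.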